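Changing the amine side chain of compound 3

A few compounds are considered here, and "the series" means these few. Any claim that something is new, unique, unknown or untested is made for them only; others in the source may bear on it.

Measured in a functional assay on HeLa cells (Homo sapiens) for antiproliferative activity, read by MTT assay, with a stated time of 48 h; on this read-out lower numbers stand for stronger inhibition and higher numbers for weaker inhibition:
Compound 1 `CN(C)CCCCn1c(N)c(C#N)c2nc(C#N)c(C#N)nc21`: > 50000 nM, a limit
Compound 2 `CCN(CC)CCn1c(N)c(-c2nc3cc(Cl)ccc3[nH]2)c2nc(C#N)c(C#N)nc21`: > 50000 nM, a limit
Compound 3 `CCN(CC)CCCn1c(N)c(-c2nc3cc(Cl)ccc3[nH]2)c2nc(C#N)c(C#N)nc21`: 24400 nM

Among the compounds with values here, compound 3 gives 24400 nM, the only actual number in this small set. The other two results are not numbers, for the set meets (the limit of > 50000 nM in this assay, at which 2 of the 3 values shown sit).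

The next compound is compound 4 `CN(C)CCCCn1c(N)c(-c2nc3cc(Cl)ccc3[nH]2)c2nc(C#N)c(C#N)nc21`, which keeps the core and the substituted ring system of compound 3 and alters only the side chain: (dimethylamino)methyl in place of diethylamino on a saturated chain carbon, three bonds along the chain from an aromatic nitrogen. Cut one bond further out, the same difference reads 3-(diethylamino)propyl to 4-(dimethylamino)butyl.

Within the data shown here, one measured step bears on this, an at least 2.0-fold lower number from compound 2 to compound 3 (0.31 log units; beyond the scatter), and it also lengthened the chain, so a further modest lowering of the number is expected. The size of that step is only a bound, since compound 2 stands at a limit. Among the measured compounds shown here, no measured step covers the exchange of diethylamino for dimethylamino on its own, so the expectation is loose. The estimated change is a 2.2-fold lower number from compound 3 to compound 4 (0.35 log units; beyond the scatter).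

Compound 4 is expected at about 11000 nM, with an estimated range of 4000 nM to 35000 nM.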

Compound 4, half-maximal inhibitory concentration: 3120 nM
Beside the measured number, compound 4's estimate is 3.5-fold (0.55 log units) above it; measured number outside the range, below it.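

In this assay, the side chain turns out to be a place where the number can move well beyond the scatter, with a 7.8-fold lower number from compound 3 to compound 4 (0.89 log units; beyond the scatter) when 3-(diethylamino)propyl gives way to 4-(dimethylamino)butyl, and compound 4 is the most potent of the set. Measured against the shorter chain, the side-chain change gives an at least 16-fold lower number from compound 2 to compound 4 (1.20 log units; beyond the scatter), while the exchange of cyano for 5-chloro-1H-benzimidazol-2-yl on an aromatic carbon, with the 4-(dimethylamino)butyl chain held constant, gives an at least 16-fold lower number from compound 1 to compound 4 (1.20 log units; beyond the scatter), the first sign that this ring substituent also matters when the side chain stays the same. Both of these sizes are only bounds, as compound 1 and compound 2 each stand at a limit: the limit of > 50000 nM in this assay, at which 2 of the 4 values shown sit.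

The change to compound 4 lengthens the chain and swaps the groups on the amine at once, and the compounds shown do not separate the two effects. A 4-(diethylamino)butyl or 3-(dimethylamino)propyl chain would pull them apart, while a 5-(dimethylamino)pentyl or 4-(piperidin-1-yl)butyl chain would test whether the lowering continues beyond compound 4.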